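The source may hold more compounds than are shown below. What is called first, only, known or untested is meant among the compounds shown, and "the series" means these compounds.

Compound 3 `COc1ccc(S(=O)(=O)c2cnc3ccc(Cl)cc3c2N2CCC(C)CC2)cc1Cl` has the lowest number of the three compounds measured in an assay on isolated protein for displacement of a labelled ligand from metabotropic glutamate receptor 5 (Homo sapiens), with a stated time of 60 min, tested at 1 uM; a higher number here means more inhibition at the concentration tested (going by the name of the read-out), a lower number less inhibition: compound 3 gives 46%, while compound 2 `CC1CCN(c2c(S(=O)(=O)c3ccccc3)cnc3ccc(Cl)cc23)CC1` gives 59% and compound 1 `Cc1ccc(S(=O)(=O)c2cnc3ccc(Cl)cc3c2N2CCC(C)CC2)cc1C` gives 84%. Both steps down to compound 3 lie beyond the scatter: a number 38 percentage points lower from compound 1 to compound 3 (beyond the scatter) and a number 13 percentage points lower from compound 2 to compound 3 (beyond the scatter). Compound 4 `Cc1ccc(S(=O)(=O)c2cnc3ccc(Cl)cc3c2N2CCC(C)CC2)cc1Cl` differs from compound 3 in one place: methyl in place of methoxy on an aromatic carbon. This moves the group on the sulfonyl sulfur part of the way back toward that of compound 1, so the large step of a number 38 percentage points lower from compound 1 to compound 3 (beyond the scatter) and the modest step of a number 13 percentage points lower from compound 2 to compound 3 (beyond the scatter) bear on it, and an upward step in this assay is expected, smaller than a full return to compound 1. For compound 4 an inhibition of 65% is estimated, in the range 45% to 85%, meaning an expected step of a number 19 percentage points higher from compound 3 to compound 4 (beyond the scatter).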

Compound 4, a percentage reported as inhibition, at one concentration (the size of the read-out at that concentration, not a potency): 81%
The estimate for compound 4 lay 16 percentage points below the measured number, and the stated range covers the measured number.
By their numbers in this assay, from the lowest: compound 3; then compound 2; then compounds 4 and 1 (each within the scatter of the next).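

In this assay, methyl in place of methoxy gives (a number 35 percentage points higher from compound 3 to compound 4 (beyond the scatter)), which places the low number of compound 3 with the methoxy rather than with the chloro group. Chloro in place of methyl on the other aromatic carbon makes no readable difference (a number 3 percentage points lower from compound 1 to compound 4 (within the scatter)), so that carbon accepts either group in this pair. The 3-chloro-4-methylphenyl group also stands clear of plain phenyl (a number 22 percentage points higher from compound 2 to compound 4 (beyond the scatter)).

From the compounds shown here alone, how an ethyl, a hydroxyl or an amine would behave at the carbon para to the large group remains open. Nothing measured here explains why the methoxy and methyl groups differ.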